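The source may report more compounds than this note shows. Statements on the series, on what has been measured and on what is new or still open speak of the compounds shown alone.

Measured compounds:
compound 1 `Oc1ccc(/C=N/NC(=S)Nc2cccc(Cl)c2)cc1` gives 29300 nM in an assay for inhibition of ribonucleoside-diphosphate reductase RR1 (Homo sapiens), with a stated time of 30 min; a higher number here means a weaker inhibitor, a lower number a stronger inhibitor
compound 2 `Cc1ccccc1NC(=S)N/N=C/c1ccc(O)cc1` gives 36500 nM in this assay

Both compounds share the same core and differ only in the substituted phenyl on the thiourea nitrogen. In this assay compound 2 and compound 1 lie within the usual scatter of each other, so no difference between the two can be read from these numbers; both are weak inhibitors on this scale.

The step to compound 3 `O=[N+]([O-])c1ccccc1NC(=S)N/N=C/c1ccc(O)cc1` is a single change: nitro in place of methyl on an aromatic carbon. Within the data shown here, no measured pair covers this change, so there is no recorded step to lean on. Among the measured compounds shown here, with only two numbers available, and those indistinguishable, the working assumption is a small step, if any, from compound 2 to compound 3 in this assay, not clearly beyond the scatter in either direction. The expected step is a 1.5-fold lower number from compound 2 to compound 3 (0.16 log units; within the scatter). On that basis compound 3 is estimated at 25000 nM in this assay, with a range from 8000 nM to 80000 nM.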

Compound 3, half-maximal inhibitory concentration: 39300 nM
For compound 3 the middle estimate is 1.6-fold (0.20 log units) below the measured one; the range from low to high includes it.
By their numbers in this assay, from the lowest: compounds 1, 2 and 3 (each within the scatter of the next).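

In this assay, among these compounds, nitro in place of methyl on an aromatic carbon ortho to a large group gives a 1.1-fold higher number from compound 2 to compound 3 (0.03 log units; within the scatter) and provides the first recorded step. At this position, a group of 3 heavy atoms with 2 hydrogen-bond acceptors can therefore replace a group of 1 heavy atom with none, without a difference that can be read from this assay. Nothing available bears on why these two groups cannot be told apart here, so the result remains an observation about this one pair.

From the compounds shown here alone, whether an amine, a carboxylic acid or a methoxy group on this same aromatic carbon would move the number beyond the scatter remains open, and a single pair cannot show how far the observation extends to other groups at this position. Also open, going by these compounds, is whether replacing the hydroxyl of the shared core with a methoxy group or an amine would separate any compound from the close values seen so far.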